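The compounds below may be only part of what the source reports. "The series", "measured", "known", "first", "only" and "open" are said of these compounds alone.

Of the compounds shown here, two have so far been tested in a functional assay on HCT-116 cells (Homo sapiens) for antiproliferative activity, read by MTT assay, with a stated time of 48 h; on this read-out lower numbers stand for stronger inhibition and higher numbers for weaker inhibition. Compound 1, with the structure `Cc1ccc(-n2nncc2CN2C(=O)C3(C(C#N)=C(N)Oc4c3c3nc5ccccc5nc3c3ccccc43)c3ccccc32)cc1C`, sits at the limit of the assay, > 50000 nM, which is a limit rather than a number. Compound 2, with the structure `N#CC1=C(N)Oc2c(N)cc3nc4ccccc4nc3c2C12C(=O)N(Cc1cnnn1-c1cccc(Br)c1)c1ccccc12`, gives 26100 nM in this assay, the only number shown among the two results. The remaining result is the limit of > 50000 nM in this assay, at which 1 of the 2 values shown sits. Compound 3, with the structure `CCc1cccc(CC)c1-n1nncc1CN1C(=O)C2(C(C#N)=C(N)Oc3c(N)cc4nc5ccccc5nc4c32)c2ccccc21`, differs from compound 2 in one place: 2,6-diethylphenyl in place of 3-bromophenyl on an aromatic nitrogen. Within the data shown here, no two measured compounds differ in a single place, so no measured step tells how large such a change has been. The step from compound 2 to compound 3 in this assay is expected to stay within the usual scatter, in either direction, at a 1.0-fold lower number from compound 2 to compound 3 (0.02 log units; within the scatter). Compound 3 is therefore estimated at 25000 nM, with a range from 8000 nM to 80000 nM.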

Compound 3, half-maximal inhibitory concentration: 37600 nM
Beside the measured number, compound 3's estimate is 1.5-fold (0.18 log units) below it, within the range that was stated.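

In this assay, among these compounds, the exchange of 3-bromophenyl for 2,6-diethylphenyl on the aromatic nitrogen comes out as a 1.4-fold higher number from compound 2 to compound 3 (0.16 log units; within the scatter) and gives the first measured step at this position. For this one pair, replacing a bromine-bearing phenyl ring with a larger, all-carbon phenyl group carrying two ethyl chains does not move the read-out beyond the usual scatter. Among the compounds shown here, nothing measured so far offers a reason for this result.

A single pair cannot show whether this position is insensitive to change in general or whether these two groups merely happen to give similar numbers. Going by these compounds, what an amine or a carboxylic acid on that phenyl ring would do remains open, as does the effect of replacing the ring with a longer alkyl chain.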